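The source may report more compounds than this note shows. Statements on the series, on what has been measured and on what is new or still open speak of the compounds shown alone.

Working notes on the series.

Compound 1 `COc1cccc(-c2c(S(=O)(=O)c3ccc(OC)c(Cl)c3)cnc3cc(F)ccc23)c1` gives 1.71 mL/min in an ADME assay on microsomes from liver (Homo sapiens) for metabolic stability, tested at 2.5 uM; a higher number here means faster removal of the compound, a lower number slower removal. Compound 2 `COc1ccc(S(=O)(=O)c2cnc3cc(F)ccc3c2-c2ccc(F)cc2)cc1Cl` gives 1.29 mL/min in this assay. Compound 3 `O=S(=O)(c1cccc(F)c1)c1cnc2c(F)cccc2c1-c1ccc(F)cc1` is the lowest of the three and gives 0.19 mL/min in this assay; how its core differs from that of compound 2 is not broken down here.

One change recurs twice among these compounds: 3-methoxyphenyl in place of 4-fluorophenyl on an aromatic carbon. Across it the measured step is a 1.3-fold higher number from compound 2 to compound 1 (0.12 log units; within the scatter).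

Compound 4 `COc1cccc(-c2c(S(=O)(=O)c3cccc(F)c3)cnc3c(F)cccc23)c1` carries the same change on the core of compound 3: 3-methoxyphenyl in place of 4-fluorophenyl on an aromatic carbon. Because the measured step of a 1.3-fold higher number from compound 2 to compound 1 (0.12 log units; within the scatter) stays within the scatter, a similarly small step is expected here, a 1.3-fold higher number from compound 3 to compound 4 (0.12 log units; within the scatter). In this assay compound 4 is accordingly estimated at 0.25 mL/min, with a range from 0.12 mL/min to 0.55 mL/min expected.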

Compound 4, intrinsic clearance in a liver preparation (reported as CLH), per the amount of preparation that the assay uses: 2.6 mL/min
Beside the measured number, compound 4's estimate is 10-fold (1.02 log units) below it; measured number above the stated range.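

In this assay, 3-methoxyphenyl in place of 4-fluorophenyl gives a 14-fold higher number from compound 3 to compound 4 (1.14 log units; beyond the scatter). The size of this step therefore does not carry over from one core to the other in this series: the same change on two cores in this assay, a 1.3-fold higher number (0.12 log units; within the scatter) from compound 2 to compound 1 and a 14-fold higher number (1.14 log units; beyond the scatter) from compound 3 to compound 4, 10-fold (1.01 log units) apart, beyond the scatter of two such steps This does not show which feature of the cores sets the size of the step, as they differ in more than one place and no compound shown separates those differences.

Still open, from the compounds shown here alone, is how the change behaves on any further core. Also open, going by these compounds, is how the read-out responds when an amine or a carboxylic acid stands on that aromatic carbon instead of either aryl group.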